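A few compounds are considered here, and "the series" means these few. Any claim that something is new, unique, unknown or untested is made for them only; others in the source may bear on it.

Compound 1 `S=C(Nc1ccccc1)N1N=C(c2ccc(Cl)cc2)CC1c1ccc2c(c1)OCCO2` gives > 200000 nM in a functional assay on HCT-116 cells (Homo sapiens) for antiproliferative activity, read by MTT assay, with a stated time of 48 h (a higher number here means a weaker inhibitor of growth, a lower number a stronger inhibitor of growth), a limit of the assay.
Compound 2 `Cc1ccc(C2=NN(C(=S)Nc3ccccc3)C(c3ccc4c(c3)OCCO4)C2)cc1` gives > 200000 nM in this assay, also a limit.
Compound 3 `COc1ccccc1C1=NN(C(=S)Nc2ccccc2)C(c2ccc3c(c2)OCCO3)C1` gives > 200000 nM in this assay, again a limit.

Compound 2 thus stands only at a limit, as do both of its neighbours: the limit of > 200000 nM in this assay, at which 3 of the 3 values shown sit. The steps around it, a step that the two limits leave unreadable from compound 1 to compound 2 and a step that the two limits leave unreadable from compound 2 to compound 3, and likewise a step that the two limits leave unreadable from compound 1 to compound 3, carry no readable size. Compound 4 `S=C(Nc1ccccc1)N1N=C(c2ccc(OCc3ccccc3)cc2)CC1c1ccc2c(c1)OCCO2` differs from compound 2 by benzyloxy in place of methyl on an aromatic carbon. Going by the values given here, none of the measured steps yields a readable size, so no direction can be drawn for this change in this assay; the expectation is simply that compound 4 will again sit at or near the limit. Compound 4 is therefore estimated at 250000 nM, within 50000 nM to 1000000 nM. The step that the limit leaves unreadable from compound 2 to compound 4 is what this estimate means.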

Compound 4, concentration for 50% growth inhibition: 8530 nM
The estimate for compound 4 lay 29-fold (1.47 log units) above the measured number, and the stated range ends above it.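

Benzyloxy on this aromatic carbon, in place of methyl or chloro, brings the number into the readable range of this assay, with an at least 23-fold lower number from compound 2 to compound 4 (1.37 log units; beyond the scatter) and with an at least 23-fold lower number from compound 1 to compound 4 (1.37 log units; beyond the scatter). This position therefore responds to change, which the earlier compounds could not show, since the steps among them cannot be read: the limit of > 200000 nM in this assay, at which 3 of the 4 values shown sit.

The compounds shown leave open whether the oxygen or the added aromatic ring of benzyloxy accounts for these steps. A methoxy, phenyl or benzyl group on the same carbon would help separate the two.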